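This account rests on a few compounds, and the source may have more. Where it says the series, first, only, none or still open, it means among the compounds named here.

Compound 1 `C[Se]c1nc(N)c2cccnc2n1`: 44100 nM
Compound 2 `CCCCC[Se]c1nc(NCc2ccccc2)c2ccccc2n1`: 72700 nM
Compound 3 `CCCCC[Se]c1nc(NCc2ccc(SC)cc2)c2ccccc2n1`: 83600 nM

In a functional assay on HT-29 cells (Homo sapiens) for cytotoxicity, read by MTT assay, with a stated time of 72 h (on this read-out lower numbers stand for stronger inhibition of growth and higher numbers for weaker inhibition of growth), compound 3 gives a number that lies within the scatter of the other two, compound 2 being nearest and compound 1 furthest. Compound 4 `CSc1ccc(CNc2nc(SC)nc3ccccc23)cc1` differs from compound 3 by a group of 2 heavy atoms (1 carbon, 1 sulfur; no ring) in place of a group of 6 heavy atoms (5 carbon, 1 selenium; no ring), on an aromatic carbon. Among the compounds with values here, no measured step touches this position; the only measured step, a 1.1-fold higher number from compound 2 to compound 3 (0.06 log units; within the scatter), changes a different part of the molecule and stays within the scatter. Because compound 2 gave 72700 nM and compound 3 gave 83600 nM, compound 4 is expected to give a number of similar size, with no step beyond the scatter expected in a 1.1-fold higher number from compound 3 to compound 4 (0.03 log units; within the scatter). Compound 4 is therefore estimated at 90000 nM, with a range from 30000 nM to 300000 nM.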

Compound 4, concentration for 50% growth inhibition: 34700 nM
Compound 4: the middle estimate sits 2.6-fold (0.41 log units) above what was measured, within the range that was stated.
By their numbers in this assay, from the lowest: compounds 4, 1, 2 and 3 (each within the scatter of the next, the first and the last beyond it).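

In this assay, within the data shown here, the change at this carbon between two ring nitrogen atoms gives a 2.4-fold lower number from compound 3 to compound 4 (0.38 log units; beyond the scatter), a modest gain in growth inhibition and the first step here beyond the scatter. The swap replaces selenium with sulfur and also leaves a much smaller group, so the two changes arrive together. No measurement available here explains the step.

From the compounds shown here alone, whether the atom or the size of the group matters more remains open, and a pentylsulfanyl group at this position could separate them. Going by these compounds, how an amine would behave here is also open.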